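This account rests on a few compounds, and the source may have more. Where it says the series, first, only, none or still open, it means among the compounds named here.

Measured compounds:
- compound 1, `COc1ccc(Cc2cnc(CCc3ccc(-c4ccccc4C(=O)O)cc3)[nH]2)cc1`: 513 nM
- compound 2, `O=C(O)c1ccccc1-c1ccc(CCc2ncc(Cc3ccccc3F)[nH]2)cc1`: 9.5 nM
- compound 3, `N#Cc1cccc(Cc2cnc(CCc3ccc(-c4ccccc4C(=O)O)cc3)[nH]2)c1`: 20 nM

In an in vitro functional assay on cells for agonist activity at Bombesin receptor subtype-3 (Mus musculus), read by luminescence and calcium flux (a higher number here means that more compound is needed for the effect, a lower number that less compound is needed), compound 3 gives 20 nM and stands second highest of the three numbers. Its nearest neighbour is compound 2, reached by a 2.1-fold higher number from compound 2 to compound 3 (0.32 log units; beyond the scatter); its furthest is compound 1, from which it is reached by a 26-fold lower number from compound 1 to compound 3 (1.41 log units; beyond the scatter).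

Compound 4, `N#Cc1ccccc1Cc1cnc(CCc2ccc(-c3ccccc3C(=O)O)cc2)[nH]1`, has not yet been measured in this assay. It differs from compound 3 in one place: 2-cyanophenyl in place of 3-cyanophenyl on a saturated chain carbon bound to an aromatic carbon.

Among the measured compounds shown here, no measured step moves a nitrile from one position of the phenyl ring to another, so the bearing of the earlier steps is indirect. The step of a 54-fold lower number from compound 1 to compound 2 (1.73 log units; beyond the scatter) and the step of a 26-fold lower number from compound 1 to compound 3 (1.41 log units; beyond the scatter) both show that leaving the 4-methoxyphenyl gives a much lower number, and the step of a 2.1-fold higher number from compound 2 to compound 3 (0.32 log units; beyond the scatter) shows that a 2-fluorophenyl and a 3-cyanophenyl sit close together, with the 2-fluorophenyl somewhat lower. Compound 4 keeps the nitrile and is therefore expected to stay in the same region as compound 3, with at most a modest change in either direction, a 1.3-fold lower number from compound 3 to compound 4 (0.12 log units; within the scatter) being the step expected. For compound 4 the estimated value in this assay is 15 nM, with a range from 5 nM to 60 nM.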

Compound 4, half-maximal effective concentration: 642 nM
Estimate against measurement, compound 4: 43-fold (1.63 log units) below; the whole stated range lies below it.
By their numbers in this assay, from the lowest: compound 2; then compound 3; then compounds 1 and 4 (each within the scatter of the next).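

Moving the nitrile alone, with the same atoms joined differently, is enough to change the result in this assay: a 32-fold higher number from compound 3 to compound 4 (1.51 log units; beyond the scatter). So at this place on a saturated chain carbon bound to an aromatic carbon, the earlier compounds' contrast between the 4-methoxyphenyl and the other two groups is not simply a matter of which substituent is present, since a nitrile can give either of the two levels seen so far, and compound 4 sits level with compound 1, a 1.3-fold higher number from compound 1 to compound 4 (0.10 log units; within the scatter). The 2-substituted pair adds a second sharp contrast, a 68-fold higher number from compound 2 to compound 4 (1.83 log units; beyond the scatter), so the 2-fluorophenyl result does not carry over to the 2-cyanophenyl, and nothing shown here gives a measured reason for either step.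

The compounds shown leave open whether the nitrile's effect is specific to the 2-cyanophenyl or would also appear with a chlorine or an amide on that ring. They also do not show how an unsubstituted phenyl at this place compares, which would tell whether the 3-cyanophenyl and 2-fluorophenyl lower the number or the 2-cyanophenyl and 4-methoxyphenyl raise it.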